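The source may hold more compounds than are shown below. What is called first, only, known or untested is meant among the compounds shown, and "the series" means these compounds.

Measured compounds in the series:
Compound 1 `N#CC1=C(N)Oc2c(c3nc4ccccc4nc3c3ccccc23)C12C(=O)N(Cc1cnnn1-c1ccc(S(N)(=O)=O)cc1)c1ccccc12` in a functional assay on HepG2 cells (Homo sapiens) for antiproliferative activity, read by MTT assay, with a stated time of 48 h (on this read-out higher numbers stand for weaker inhibition and lower numbers for stronger inhibition), gives 42200 nM.
Compound 2 `Cc1ccc(-n2nncc2CN2C(=O)C3(C(C#N)=C(N)Oc4c3c3nc5ccccc5nc3c3ccccc43)c3ccccc32)cc1Cl` gives, as a limit of the assay and not a number, > 50000 nM.
Compound 3 `CCOc1ccccc1-n1nncc1CN1C(=O)C2(C(C#N)=C(N)Oc3c(N)cc4nc5ccccc5nc4c32)c2ccccc21` gives 30500 nM.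

Compound 3 has the lowest of the two numbers shown; its nearest neighbour is compound 1, whose number is higher by a margin that stays within the scatter, so the two cannot be put in order. Compound 2 sits at the limit (the limit of > 50000 nM in this assay, at which 1 of the 3 values shown sits), so only a floor is known for it.

The next compound, compound 4 `COc1cc(-n2nncc2CN2C(=O)C3(C(C#N)=C(N)Oc4c(N)cc5nc6ccccc6nc5c43)c3ccccc32)c(OC)cc1Cl`, differs from compound 3 only at the aryl on the aromatic nitrogen: 4-chloro-2,5-dimethoxyphenyl in place of 2-ethoxyphenyl on an aromatic nitrogen.

For the measured compounds named here, the one measured step that bears on this is the swap of the aryl on the same aromatic nitrogen, an at least 1.1-fold higher number from compound 1 to compound 2 (0.07 log units; that floor lies within the scatter). It reads only as a floor, and that floor lies within the scatter, so it shows no clear sensitivity of this assay to which aryl sits there. No larger effect is therefore expected from compound 3 to compound 4; the change is expected to be a 1.1-fold higher number from compound 3 to compound 4 (0.06 log units; within the scatter), a shift not beyond the scatter, with a risk that compound 4 also returns only a limit.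

Compound 4 is expected to give about 35000 nM, with a range from 15000 nM to 50000 nM.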

Compound 4, half-maximal inhibitory concentration: > 50000 nM
Compound 4 gave a limit, no number; the forecaster's own chance of this, stated with the estimate: 30%; at least 1.4-fold (0.15 log units) between middle value and limit.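

In this assay compound 4 returns a limit and not a number, the same limit as compound 2: the limit of > 50000 nM in this assay, at which 2 of the 4 values shown sit.

On the core of compound 3, the exchange of 2-ethoxyphenyl for 4-chloro-2,5-dimethoxyphenyl reads as an at least 1.6-fold higher number from compound 3 to compound 4 (0.21 log units; that floor lies within the scatter), so this change is not shown to be a real shift, though its true size may be greater than that floor. The same holds for the earlier swap on the other core, an at least 1.1-fold higher number from compound 1 to compound 2 (0.07 log units; that floor lies within the scatter). What is new is that the aryl on this aromatic nitrogen has now been changed on two different cores, each time going from a measured number to a limit, so neither swap gives any sign of a lower number, and neither gives a size for the change.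

On these data alone, how far compound 2 and compound 4 lie past the limit stays open, and with it whether the aryl at this position matters at all in this assay. Also open, as far as these compounds go, is what an aryl carrying an amine or a carboxylic acid, or a longer chain in place of the ethoxy group of compound 3, would give on this nitrogen.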